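Changing the ring on the amine nitrogen

This account rests on a few compounds, and the source may have more. Where it says the series, first, only, none or still open, it means among the compounds named here.

Within the data shown here, in an ADME assay on the whole organism with Canis familiaris (Canis lupus familiaris) as the target (a lower number here means that the compound disappears faster, a higher number that the compound lasts longer), compound 2 `CCO/C(O)=C1\C(COCCNc2noc(N)n2)=NC(C)=C(C(=O)OC)C1c1cccc(Cl)c1Cl` gives 0.3 h, the only exact number so far. Compound 1 `CCO/C(O)=C1\C(COCCNc2n[nH]c(N)n2)=NC(C)=C(C(=O)OC)C1c1cccc(Cl)c1Cl` gives > 7 h, which is a limit of the assay and not a number. Among the measured compounds shown here, the one measured step, an at least 23-fold lower number from compound 1 to compound 2 (1.36 log units; beyond the scatter), is large and beyond the scatter, and it exchanges only the group on the amine nitrogen. Compound 3 `CCO/C(O)=C1\C(COCCNc2nccc(O)n2)=NC(C)=C(C(=O)OC)C1c1cccc(Cl)c1Cl` changes that same group again: 4-hydroxypyrimidin-2-yl in place of 5-amino-1,2,4-oxadiazol-3-yl on an amine nitrogen. With compound 2 at 0.3 h, a rise is expected, though one step is thin support. The expected change is a 6.7-fold higher number from compound 2 to compound 3 (0.82 log units; beyond the scatter). Compound 3 is estimated at 2 h, within a range from 0.4 h to 9 h.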

Compound 3, half-life: 4.3 h
Estimate against measurement, compound 3: 2.2-fold (0.33 log units) below, and the stated range covers the measured number.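

In this assay, the low number of compound 2 proves specific to the 5-amino-1,2,4-oxadiazol-3-yl rather than common to every replacement on this amine nitrogen: a 14-fold higher number from compound 2 to compound 3 (1.16 log units; beyond the scatter). The other comparison gives an at least 1.6-fold lower number from compound 1 to compound 3 (0.21 log units; that floor lies within the scatter), which is only a floor. The value of compound 1 is a limit and not a number, so the true size of that gap cannot be read: the limit of > 7 h in this assay, at which 1 of the 3 values shown sits.

Still open, going by these compounds, is how a group without a ring, such as acetyl or methyl, would behave on this amine nitrogen.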